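Hydroxy for trifluoromethyl on the arylurea of the series

The source may report more compounds than this note shows. Statements on the series, on what has been measured and on what is new or still open speak of the compounds shown alone.

The three measured compounds share one core and differ in the aryl group on the outer urea nitrogen. Compound 1 `COc1cc(NC(C)CCCNC(=O)NNC(=O)Nc2ccc(C(F)(F)F)cc2)c2ncccc2c1` carries 4-(trifluoromethyl)phenyl; in a functional assay on HeLa cells (Homo sapiens) for inhibition, read by MTT assay, with a stated time of 72 h (on this read-out higher numbers stand for weaker inhibition and lower numbers for stronger inhibition), compound 1 gives 15000 nM, the highest number of the three. Compound 2 `COc1cc(NC(C)CCCNC(=O)Nc2cccc(C(F)(F)F)c2)c2ncccc2c1`, with a single urea link, gives 14000 nM, within the scatter of compound 1. Compound 3 `COc1cc(NC(C)CCCNC(=O)NNC(=O)Nc2cccc(C(F)(F)F)c2)c2ncccc2c1` gives 4900 nM; the step of a 3.1-fold lower number from compound 1 to compound 3 (0.49 log units; beyond the scatter) is the only one in the set that lies beyond the scatter.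

Compound 4 `COc1cc(NC(C)CCCNC(=O)NNC(=O)Nc2ccc(O)cc2)c2ncccc2c1` is not yet measured. Against compound 1 it shows (hydroxy in place of trifluoromethyl on an aromatic carbon). Among the compounds with values here, no measured step covers a change of this kind: the one step beyond scatter moves the trifluoromethyl around the ring rather than replacing it, and the step from compound 1 to compound 2 changes the linker. The number for compound 4 is therefore expected to stay near that of compound 1 in this assay, with a wide range; the estimated step is a 1.3-fold higher number from compound 1 to compound 4 (0.12 log units; within the scatter). The estimated value for compound 4 is 20000 nM, expected between 5000 nM and 60000 nM.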

Compound 4, half-maximal inhibitory concentration: 85000 nM
The estimate for compound 4 lay 4.3-fold (0.63 log units) below the measured number, outside the stated range (above it).
By their numbers in this assay, from the lowest: compound 3; then compounds 2 and 1 (each within the scatter of the next); then compound 4.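

In this assay, within the data shown here, the step of a 5.7-fold higher number from compound 1 to compound 4 (0.75 log units; beyond the scatter) is the first measured exchange of the trifluoromethyl itself, and it shows that the number responds to the group on this aromatic carbon, not only to where the trifluoromethyl sits. The gap is wider in a 17-fold higher number from compound 3 to compound 4 (1.24 log units; beyond the scatter) and similar in a 6.1-fold higher number from compound 2 to compound 4 (0.78 log units; beyond the scatter), though both of these pairs differ by more than the hydroxy alone, and compound 4 has the highest number of the four, beyond the scatter of each. Nothing available here bears on why the hydroxy gives the higher number.

Going by these compounds, it remains open whether the same exchange on the aryl group of compound 3 or compound 2 gives a step of like size. Also open, on these data alone, is how an amine, a carboxylic acid or a methoxy group in place of the hydroxy would read in this assay.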